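This account rests on a few compounds, and the source may have more. Where it says the series, first, only, none or still open, it means among the compounds named here.

Measured so far:
compound 1, `C[Si](C)(C)c1ccc2nc(N)sc2c1`: 5 mg/kg
compound 2, `CCCCCCCc1ccc2nc(N)sc2c1`: > 10 mg/kg
compound 3, `C#CCn1c(=N)sc2cc(OC(F)(F)F)ccc21`: 4 mg/kg

All three have been run in a functional assay on the whole organism with Rattus norvegicus as the target; on this read-out higher numbers stand for an effect only at larger amounts of compound and lower numbers for an effect already at smaller amounts. Compound 3 gives 4 mg/kg, the lowest of the two numbers shown. Compound 1 gives 5 mg/kg, which lies within the scatter of compound 3, so no order between these two can be read from this assay. For compound 2 the entry > 10 mg/kg is a limit of this assay and not a number; it sits at the limit of > 10 mg/kg in this assay, at which 1 of the 3 values shown sits.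

Compound 4, `N=c1sc2cc(OC(F)(F)F)ccc2n1CCO`, has not yet been run in this assay. Against compound 3 the change is hydroxymethyl in place of ethynyl on a saturated chain carbon bound to an aromatic nitrogen. Among the measured compounds shown here, no step between measured compounds covers this exchange, so the expectation rests on the change alone and on the value of compound 3. The replacement of ethynyl by hydroxymethyl on a saturated chain carbon bound to an aromatic nitrogen is expected to move this assay little, with no direction that the data support; a step of the size of the scatter in either direction would not surprise. The expected step is a 1.3-fold higher number from compound 3 to compound 4 (0.10 log units; within the scatter), within the scatter. Compound 4 is estimated at 5 mg/kg, with a range from 2 mg/kg to 12 mg/kg.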

Compound 4, dose for half-maximal effect: 8 mg/kg
Beside the measured number, compound 4's estimate is 1.6-fold (0.20 log units) below it; measured number inside the range.
By their numbers in this assay, from the lowest: compounds 3, 1 and 4 (each within the scatter of the next). At a limit, above all of these: compound 2.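

Hydroxymethyl in place of ethynyl on a saturated chain carbon bound to an aromatic nitrogen gives, in this assay, a 2.0-fold higher number from compound 3 to compound 4 (0.30 log units; within the scatter), the first step in the series read between two compounds that differ in one place only. This place on the shared core therefore takes propargyl and 2-hydroxyethyl with no separation beyond the scatter, even though the group that enters carries a hydrogen-bond donor and acceptor and the group that leaves carries neither, and the triple bond is lost with it. No measurement shown bears on what lies behind the size of this step.

From the compounds shown here alone, whether an amine or a carboxylic acid at the end of this chain, or a longer chain, would give a step beyond the scatter stays open, since a single exchange at this place gives no trend. Compound 1 and compound 2 differ from compound 3 in more than one place, so the part played by the trifluoromethoxy group on the core also stays unresolved.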